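From compound 2 to compound 4: an aryl exchange

The source may report more compounds than this note shows. Statements on the series, on what has been measured and on what is new or still open speak of the compounds shown alone.

Values in a functional assay on PC-3 cells (Homo sapiens) for cytotoxicity, read by MTT assay, with a stated time of 72 h (on this read-out lower numbers stand for stronger inhibition and higher numbers for weaker inhibition), are as follows.
- compound 1 `CNC(=O)c1cc(Oc2ccc(C(=O)/C=C/c3ccco3)cc2)ccn1` gives "not determined" (no result reported)
- compound 2 `CNC(=O)c1cc(Oc2ccc(C(=O)/C=C/c3ccc(C#N)cc3)cc2)ccn1` gives 3870 nM
- compound 3 `CNC(=O)c1cc(Oc2ccc(C(=O)/C=C/c3cc(OC)c(OC)c(OC)c3)cc2)ccn1` gives 3150 nM

Compound 2 stands within the scatter of compound 3, so these two numbers give no order, and compound 1 adds no number. Compound 4 `CNC(=O)c1cc(Oc2ccc(C(=O)/C=C/c3cccc(Cl)c3Cl)cc2)ccn1` differs from compound 2 by one exchange (2,3-dichlorophenyl in place of 4-cyanophenyl on a double-bonded chain carbon bound to a double-bonded chain carbon). Among the measured compounds shown here, no measured pair isolates a single change, so the basis for a step in this assay is thin. Compound 2 at 3870 nM and compound 3 at 3150 nM carry different groups at this place, yet their values lie within the scatter. No step beyond the scatter is therefore expected. The expected step (a 1.4-fold lower number from compound 2 to compound 4 (0.14 log units; within the scatter)) is an estimate that remains within the scatter. Compound 4 is estimated at 2800 nM with an expected range from 900 nM to 8500 nM as the upper end.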

Compound 4, half-maximal inhibitory concentration: > 50000 nM
Compound 4: a limit, no number; the forecaster's own chance of this, stated with the estimate: 10%; middle value at least 17-fold (1.25 log units) away from the limit.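

In this assay, exchanging 4-cyanophenyl for 2,3-dichlorophenyl on a double-bonded chain carbon bound to a double-bonded chain carbon gives an at least 12-fold higher number from compound 2 to compound 4 (1.11 log units; beyond the scatter). This place therefore responds to the aryl group, which compound 2 and compound 3, within the scatter of each other, did not show. The reading for compound 4 is a limit and not a number, so the full size of the step stays unknown: the limit of > 50000 nM in this assay, at which 1 of the 4 values shown sits.

As far as these compounds go, whether the step belongs to the 2,3-dichlorophenyl group as a whole or to a single chlorine stays open. Also open, from the compounds shown here alone, is how a phenyl ring carrying an amine or a carboxylic acid would read at this place.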